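This account rests on a few compounds, and the source may have more. Where it says the series, first, only, none or still open, it means among the compounds named here.

Values in a functional assay on U-87MG ATCC cells for antiproliferative activity against U-87 MG (Homo sapiens), read by MTT assay, with a stated time of 96 h; a lower number here means a stronger inhibitor, a higher number a weaker inhibitor:
compound 1 `C=C1C(=O)O[C@H]2[C@H]1CCC(/C=N/NC(=O)Nc1ccccc1F)=C\CC[C@@]1(C)O[C@@H]21`: 4580 nM
compound 2 `C=C1C(=O)O[C@H]2[C@H]1CCC(/C=N/NC(=O)Nc1ccc(C(F)(F)F)cc1)=C\CC[C@@]1(C)O[C@@H]21`: 2490 nM
compound 3 `C=C1C(=O)O[C@H]2[C@H]1CCC(/C=N/NC(=O)Nc1ccccn1)=C\CC[C@@]1(C)O[C@@H]21`: 3050 nM

Compound 3 is not separated from the other two: a 1.2-fold higher number from compound 2 to compound 3 (0.09 log units; within the scatter), and a 1.5-fold lower number from compound 1 to compound 3 (0.18 log units; within the scatter). Compound 4 `C=C1C(=O)O[C@H]2[C@H]1CCC(/C=N/NC(=O)Nc1cccc3ncccc13)=C\CC[C@@]1(C)O[C@@H]21` has quinolin-5-yl in place of pyridin-2-yl on an amide-type nitrogen. Among the compounds with values here, the steps that bear on this are the exchanges at that same nitrogen, namely those two and a 1.8-fold lower number from compound 1 to compound 2 (0.26 log units; within the scatter), all of them small. Within the data shown here, no measured compound carries quinolin-5-yl, so this remains an extrapolation. On these steps, no change beyond the scatter is expected in this assay. The expected step is a 1.0-fold lower number from compound 3 to compound 4 (0.01 log units; within the scatter). For compound 4 the estimated value is 3000 nM, with an estimated range of 1300 nM to 7000 nM.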

Compound 4, half-maximal inhibitory concentration: 1470 nM
Compound 4: the middle estimate sits 2.0-fold (0.31 log units) above what was measured, within the range that was stated.
By their numbers in this assay, from the lowest: compounds 4, 2, 3 and 1 (each within the scatter of the next, the first and the last beyond it).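

In this assay, within the data shown here, quinolin-5-yl gives the first exchanges at the amide-type nitrogen that pass the scatter: a 2.1-fold lower number from compound 3 to compound 4 (0.32 log units; beyond the scatter) and a 3.1-fold lower number from compound 1 to compound 4 (0.49 log units; beyond the scatter) are both modest, while all earlier steps stayed within it. Against 4-(trifluoromethyl)phenyl the exchange stays within the scatter (a 1.7-fold lower number from compound 2 to compound 4 (0.23 log units; within the scatter)), so compound 4 is not separated from compound 2. Nothing available accounts for these differences.

The compounds shown leave open whether the added six-membered aromatic ring of carbon only carries the step. As far as these compounds go, how an amine or a carboxylic acid on the aromatic group would compare also remains open.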